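This account rests on a few compounds, and the source may have more. Where it says the series, first, only, none or still open, it means among the compounds named here.

Working notes on the amide series built on the shared core. Compound 1 `O=C(CCc1cccc2c1B(O)OC2)NC1CCCCC1` carries a cyclohexyl on the amide-type nitrogen; in a functional assay on MDA-MB-231 cells (Homo sapiens) for antiproliferative activity, read by MTT assay, with a stated time of 72 h (a lower number here means a stronger inhibitor, a higher number a weaker inhibitor), compound 1 gives only a limit, > 100000 nM, as recorded in the limit of > 100000 nM in this assay, at which 1 of the 3 values shown sits. Compound 2 `Cc1ccc(NC(=O)CCc2cccc3c2B(O)OC3)cc1` bears a 4-methylphenyl on that nitrogen, and in this assay compound 2 gives 1100 nM. Compound 3 `O=C(CCc1cccc2c1B(O)OC2)Nc1cccc(Br)c1` bears a 3-bromophenyl, and in this assay compound 3 gives 720 nM. The steps of an at least 90-fold lower number from compound 1 to compound 2 (1.95 log units; beyond the scatter) and an at least 130-fold lower number from compound 1 to compound 3 (2.14 log units; beyond the scatter) are both large, whereas the step of a 1.5-fold lower number from compound 2 to compound 3 (0.18 log units; within the scatter) is within the scatter. Compound 3 thus holds the lowest of the two full numbers, with compound 2 close to it.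

Compound 4 `CSc1cccc(-c2cccc(NC(=O)CCc3cccc4c3B(O)OC4)c2)c1` is not yet measured. It differs from compound 3 by 3-(methylsulfanyl)phenyl in place of bromo on an aromatic carbon. Among the compounds with values here, no measured step covers an aryl group entering at this place. Within the data shown here, the large steps from compound 1 concern the exchange of cyclohexyl for an aryl group, not a change on the aryl itself, and the one change among aryl substituents, a 1.5-fold lower number from compound 2 to compound 3 (0.18 log units; within the scatter), stayed within the scatter. No step beyond the scatter is therefore expected in this assay. Compound 4 is estimated at 600 nM, with a range from 150 nM to 3000 nM. This corresponds to an expected step of a 1.2-fold lower number from compound 3 to compound 4 (0.08 log units; within the scatter).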

Compound 4, half-maximal inhibitory concentration: 150 nM
Beside the measured number, compound 4's estimate is 4.0-fold (0.60 log units) above it, within the range that was stated.
By their numbers in this assay, from the lowest: compound 4; then compounds 3 and 2 (each within the scatter of the next). At a limit, above all of these: compound 1.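

In this assay the exchange of bromo for 3-(methylsulfanyl)phenyl gives a 4.8-fold lower number from compound 3 to compound 4 (0.68 log units; beyond the scatter), the only change on the aryl group itself among those shown that lies beyond the scatter. This place, on an aromatic carbon of a six-membered aromatic ring of carbon only and meta to a large group, therefore responds to substitution, and it accepts a group of 8 heavy atoms with a second aromatic ring without the number rising. The values shown do not say which part of the entering group carries the step, and no accompanying measurement bears on its origin.

Open, going by these compounds, is whether the step needs the second aromatic ring, the methylsulfanyl group or both: an unsubstituted phenyl, or a methylsulfanyl group set directly on the aromatic carbon, would separate these. Also open, on these data alone, is how an amine or a carboxylic acid on the second aromatic ring, or a longer chain leading to the amide carbonyl, would read in this assay.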